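Compound 4: a further chloro in the methylsulfonyl series

The source may report more compounds than this note shows. Statements on the series, on what has been measured and on what is new or still open speak of the compounds shown alone.

Measured so far in a functional assay on HeLa cells (Homo sapiens) for antiproliferative activity, read by MTT assay, with a stated time of 72 h; a higher number here means a weaker inhibitor, a lower number a stronger inhibitor:
compound 1 `O=C(Nc1ccc(Cl)c(-c2nnc3c(Cl)cccn23)c1)c1ccc(C(F)(F)F)cc1Cl`, where compound 1 gives > 100000 nM, a limit of the assay.
compound 2 `O=C(Nc1ccc(Cl)c(-c2nnc3c(Cl)cccn23)c1)c1ccc(Cl)cc1`, where compound 2 gives > 100000 nM, a limit of the assay.
compound 3 `CS(=O)(=O)c1ccc(C(=O)Nc2ccc(Cl)c(-c3nnc4c(Cl)cccn34)c2)cc1`, where compound 3 gives > 100000 nM, a limit of the assay.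

Going by the values given here, compound 3 thus stands at the limit, as do the two other values shown, so no compound here has a measured number, and the limit of > 100000 nM in this assay, at which 3 of the 3 values shown sit, covers all three. The step from compound 2 to compound 3 is a step that the two limits leave unreadable from compound 2 to compound 3. Compound 4 `CS(=O)(=O)c1ccc(C(=O)Nc2ccc(Cl)c(-c3nnc4c(Cl)cccn34)c2)c(Cl)c1` differs from compound 3 by chloro in place of hydrogen on an aromatic carbon. Compound 1 already carries a chloro at that place, with a trifluoromethyl instead of the methylsulfonyl, and compound 1 also sits at the limit. Among the compounds with values here, no measured step bears readably on this change, so no step beyond the scatter is expected in this assay. The step estimated is a step that the limit leaves unreadable from compound 3 to compound 4. Compound 4 is expected at 150000 nM, within 30000 nM to 1000000 nM, most likely reported as a limit again.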

Compound 4, half-maximal inhibitory concentration: > 100000 nM
Compound 4 ended at the assay's limit; the forecaster's own chance of this, stated with the estimate: 85%; the middle value lies beyond the limit too.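

No new step can be read from compound 3 to compound 4 or from compound 1 to compound 4, as both members of each pair sit at a limit: the limit of > 100000 nM in this assay, at which 4 of the 4 values shown sit.

The compounds shown leave open which structure, if any, would give a measured number rather than a limit in this assay.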